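This account rests on a few compounds, and the source may have more. Where it says the series, first, only, none or still open, it means among the compounds named here.

Measured so far in an ADME assay on MT4 cells (Homo sapiens) for cytotoxicity, read by MTT assay, with a stated time of 4 days; a higher number here means that more compound is tolerated, a lower number that less compound is tolerated:

- compound 1, `C/C(=N\NC(=O)COc1cccc2ccccc12)c1cccc([N+](=O)[O-])c1`: 12.1 ug/mL
- compound 2, `COc1ccc(/C=N/NC(=O)COc2cccc3ccccc23)cc1O`: 7.05 ug/mL
- compound 3, `COc1cc(/C=N/NC(=O)COc2cccc3ccccc23)cc(OC)c1O`: 16.3 ug/mL

All three compounds share one core and differ only in the aryl group on the carbon double-bonded to nitrogen. The three numbers form a narrow band: compound 1 falls between the other two values, yet its gap to compound 3 and its gap to compound 2 both lie within the usual scatter of this assay. For the measured compounds named here, on these numbers no compound can be called better or worse tolerated than another; the series so far reads as flat.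

The next compound, compound 4 `C/C(=N\NC(=O)COc1cccc2ccccc12)c1ccc(O)cc1`, is compared with compound 1. The change is 4-hydroxyphenyl in place of 3-nitrophenyl on a carbon with a double bond to nitrogen. Going by the values given here, no measured pair in the set isolates this change, and the three measured aryl variants, which include a nitro-bearing ring and two hydroxy-bearing rings, all landed within the scatter of each other.

The step from compound 1 to compound 4 is therefore expected to be small: a 1.0-fold lower number from compound 1 to compound 4 (0.00 log units; within the scatter), with no direction claimed beyond the scatter. Compound 4 is expected to give about 12 ug/mL in this assay, with a range from 5 ug/mL to 30 ug/mL.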

Compound 4, half-maximal cytotoxic concentration: 68.8 ug/mL
Compound 4: the middle estimate sits 5.7-fold (0.76 log units) below what was measured; the whole stated range lies below it.
By their numbers in this assay, from the lowest: compounds 2, 1 and 3 (each within the scatter of the next, the first and the last beyond it); then compound 4.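

In this assay, for the compounds shown here, the aryl group on a carbon with a double bond to nitrogen proves able to shift the read-out: 4-hydroxyphenyl in place of 3-nitrophenyl gives a 5.7-fold higher number from compound 1 to compound 4 (0.75 log units; beyond the scatter) and this is the first step that can be read at all, as the earlier compounds offered no pair differing in one place. Their narrow band therefore did not mean that this position is indifferent to the group it carries, although 3-nitrophenyl and 4-hydroxyphenyl differ both in the group on the ring and in where it sits, so this single step cannot be divided between those two differences. Going by these compounds alone, nothing measured so far bears on why the number moved.

The compounds shown leave open whether the step follows the loss of the nitro group, the arrival of the hydroxy group or the change of ring position, which 3-hydroxyphenyl, 4-nitrophenyl and unsubstituted phenyl on the same carbon would help to separate. On these data alone, it also remains open whether the higher number is particular to the hydroxy group or extends to other groups in its place, such as 4-aminophenyl or 4-carboxyphenyl.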